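Moving the Chlorines on a Urea Aryl Ring

A few compounds are considered here, and "the series" means these few. Any claim that something is new, unique, unknown or untested is made for them only; others in the source may bear on it.

Compound 1 `O=C(Nc1ccccc1)Nc1cccc(CNc2nccnc2Cl)c1`: 15600 nM
Compound 2 `O=C(Nc1cccc(CNc2nccnc2Cl)c1)Nc1ccc(Cl)cc1Cl`: 7230 nM

Going by the values given here, compound 2 holds the lower of the two numbers in a functional assay on HepG2 cells (Homo sapiens) for antiproliferative activity, read by MTT assay, with a stated time of 48 h; a higher number here means a weaker inhibitor, a lower number a stronger inhibitor; the only measured step, a 2.2-fold lower number from compound 1 to compound 2 (0.33 log units; beyond the scatter), separates it from the other. Compound 3 `O=C(Nc1cccc(CNc2nccnc2Cl)c1)Nc1ccc(Cl)c(Cl)c1` differs from compound 2 by 3,4-dichlorophenyl in place of 2,4-dichlorophenyl on an amide-type nitrogen. Among the compounds with values here, that single step concerns placing two chlorines on a bare ring, not moving them within it, so no measured step bears directly on this change. The expected step is therefore none beyond the scatter, a 1.0-fold lower number from compound 2 to compound 3 (0.01 log units; within the scatter). Compound 3 is estimated at 7000 nM, in the range 3000 nM to 17000 nM.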

Compound 3, half-maximal inhibitory concentration: 6170 nM
Estimate against measurement, compound 3: 1.1-fold (0.05 log units) above; the range from low to high includes it.
By their numbers in this assay, from the lowest: compounds 3 and 2 (each within the scatter of the next); then compound 1.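

In this assay, going from 2,4-dichlorophenyl to 3,4-dichlorophenyl on the amide-type nitrogen gives a 1.2-fold lower number from compound 2 to compound 3 (0.07 log units; within the scatter), so this assay does not tell the two chlorine arrangements apart. The 3,4-dichlorophenyl group also stands clear of plain phenyl, with a 2.5-fold lower number from compound 1 to compound 3 (0.40 log units; beyond the scatter), so a lower number than phenyl holds for both dichlorophenyl groups shown. Nothing available here accounts for either step.

The compounds shown leave open whether a single chlorine on the ring would do as much. They also leave open how a methoxy, a trifluoromethyl or an amine on this ring would compare.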